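A few compounds are considered here, and "the series" means these few. Any claim that something is new, unique, unknown or untested is made for them only; others in the source may bear on it.

Measured so far:
Compound 1 `COc1ccc2[nH]c(C(=O)N3CC(=O)N(Cc4ccccc4)[C@@H](CCc4ccccc4)C3)cc2c1`: in an ADME assay on Vero cells (Chlorocebus sabaeus) for cytotoxicity, with a stated time of 7 days (on this read-out lower numbers stand for higher toxicity in this test and higher numbers for lower toxicity in this test), compound 1 gives > 30000 nM, a limit of the assay.
Compound 2 `COc1ccc2[nH]c(C(=O)N3CC(=O)N(Cc4ccccc4)[C@@H](CN4CCC5(CC4)CC5)C3)cc2c1`: in this assay compound 2 gives 17100 nM.
Compound 3 `COc1cccc(CN2C(=O)CN(C(=O)c3cc4cc(OC)ccc4[nH]3)C[C@@H]2Cc2ccccn2)c1`: in this assay compound 3 gives > 10000 nM, a limit of the assay.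

Compound 2 holds the only number shown; the other two values are limits (the limit of > 10000 nM in this assay, at which 1 of the 3 values shown sits, (the limit of > 30000 nM in this assay, at which 1 of the 3 values shown sits)). Within the data shown here, the one step that reaches it, an at least 1.7-fold lower number from compound 1 to compound 2 (0.24 log units; that floor lies within the scatter), sits at a floor that lies within the scatter. Compound 4 `COc1ccc2[nH]c(C(=O)N3CC(=O)N(Cc4ccccc4)[C@@H](COC(C)(C)C)C3)cc2c1` carries a group of 5 heavy atoms (4 carbon, 1 oxygen; no ring) in place of a group of 8 heavy atoms (7 carbon, 1 nitrogen; one three-membered non-aromatic ring of carbon only, one six-membered non-aromatic ring with 1 hetero atom), on a saturated chain carbon bound to a saturated ring carbon. Among the measured compounds shown here, only that step bears on this change, and it is small; in this assay a step of a 1.2-fold higher number from compound 2 to compound 4 (0.07 log units; within the scatter) is expected, nothing beyond the scatter. Compound 4 is therefore estimated at 20000 nM, between 8000 nM and 40000 nM.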

Compound 4, half-maximal cytotoxic concentration: 78200 nM
Estimate against measurement, compound 4: 3.9-fold (0.59 log units) below; measured number outside the range, above it.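

In this assay this position on a saturated chain carbon bound to a saturated ring carbon proves responsive: tert-butoxy in place of the group of 8 heavy atoms gives a 4.6-fold higher number from compound 2 to compound 4 (0.66 log units; beyond the scatter), the only step shown that is beyond the scatter. The step between compound 1 and compound 4 cannot be read. Nothing measured here accounts for the size of the step.

Still open, from the compounds shown here alone, is whether the change follows the ring nitrogen leaving or the oxygen entering. A morpholine or a carboxylic acid at this place could help to separate the two.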